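The source may hold more compounds than are shown below. What is called first, only, known or untested is meant among the compounds shown, and "the series" means these compounds.

Compounds measured in a physicochemical assay for lipophilicity; on this read-out higher numbers stand for higher lipophilicity and lower numbers for lower lipophilicity
- Compound 1 `CCCCCCCN(CCCCCSc1nc(O)c2ccccc2n1)C(=O)Nc1ccc(F)cc1F` gives 6.17
- Compound 2 `CCCCCCCN(CCCCCSc1[nH]cnc2ncnc1-2)C(=O)Nc1ccc(F)cc1F` gives 5.32
- Compound 3 `CCCCCCCN(CCCCCSc1[nH]cnc2nncc1-2)C(=O)Nc1ccc(F)cc1F` gives 5.6

Compound 3 forms a lower pair with compound 2, and the two cannot be told apart (a number 0.28 log units higher from compound 2 to compound 3 (within the scatter)). Compound 4 `CCCCCCCN(CCCCCSc1n[nH]c(-c2ccccc2)n1)C(=O)Nc1ccc(F)cc1F` changes the group on the sulfur (a group of 11 heavy atoms (8 carbon, 3 nitrogen; one five-membered aromatic ring with 3 hetero atoms, one six-membered aromatic ring of carbon only) in place of a group of 9 heavy atoms (5 carbon, 4 nitrogen; one five-membered aromatic ring with 2 hetero atoms, one six-membered aromatic ring with 2 hetero atoms), on a sulfur). The entering group is 5-phenyl-1H-1,2,4-triazol-3-yl.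

The group in compound 1 also holds a six-membered aromatic ring of carbon only, so the steps away from compound 1 are the best guide (a number 0.85 log units lower from compound 1 to compound 2 (beyond the scatter) and a number 0.57 log units lower from compound 1 to compound 3 (beyond the scatter)). For the measured compounds named here, both steps are modest, and the entering group is not the same as the one in compound 1, so they guide only roughly.

Read backwards, they point to an expected modest rise (a number 0.50 log units higher from compound 3 to compound 4 (beyond the scatter)). Compound 4 is therefore estimated at 6.1, with an expected range from 5.6 to 6.6.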

Compound 4, partition coefficient: 6.78
Compound 4: the middle estimate sits 0.68 log units below what was measured, outside the stated range (above it).
By their numbers in this assay, from the lowest: compounds 2 and 3 (each within the scatter of the next); then compound 1; then compound 4.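

In this assay, the group on the sulfur can carry the number past that of compound 1: 5-phenyl-1H-1,2,4-triazol-3-yl beats 4-hydroxyquinazolin-2-yl (a number 0.61 log units higher from compound 1 to compound 4 (beyond the scatter)). The same group stands well clear of the two lower compounds (a number 1.18 log units higher from compound 3 to compound 4 (beyond the scatter); a number 1.46 log units higher from compound 2 to compound 4 (beyond the scatter)), making compound 4 the highest of the set. No measurement here explains this rise.

From the compounds shown here alone, each step swaps the whole group, so the separate shares of the phenyl ring and the triazole ring stay open. Also open, going by these compounds, is how an amine on the phenyl ring would move the number.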